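The source may hold more compounds than are shown below. What is called first, only, known or untested is meant among the compounds shown, and "the series" means these compounds.

The measured compounds, all read in a functional assay on A549 cells (Homo sapiens) for antiproliferative activity, read by MTT assay, with a stated time of 24 h; a lower number here means a stronger inhibitor, a higher number a weaker inhibitor:

Compound 1, `Cc1ccccc1-n1cc(-c2ccccc2NS(=O)(=O)c2c[nH]c(=O)[nH]c2=O)nn1`, gives 3210 nM.
Compound 2, `Cc1cccc(-n2cc(-c3ccccc3NS(=O)(=O)c3c[nH]c(=O)[nH]c3=O)nn2)c1`, gives 1870 nM.
Compound 3, `Cc1ccc(-n2cc(-c3ccccc3NS(=O)(=O)c3c[nH]c(=O)[nH]c3=O)nn2)cc1`, gives 2910 nM.

Among these three, compound 3 sits second highest, close to compound 1 and further from compound 2; all three values lie within the usual scatter of one another, so no order can be claimed. The steps tell the same story: a 1.7-fold lower number from compound 1 to compound 2 (0.23 log units; within the scatter), a 1.1-fold lower number from compound 1 to compound 3 (0.04 log units; within the scatter) and a 1.6-fold higher number from compound 2 to compound 3 (0.19 log units; within the scatter) are each within the scatter, and moving the methyl group around the phenyl ring on the aromatic nitrogen left the read-out essentially unchanged.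

Compound 4, `O=c1[nH]cc(S(=O)(=O)Nc2ccccc2-c2cn(-c3ccccc3F)nn2)c(=O)[nH]1`, is the next step from compound 3. The structural change is 2-fluorophenyl in place of 4-methylphenyl on an aromatic nitrogen. Going by the values given here, none of the measured steps exchanges a methyl group for a fluorine atom; they only bear on the position of a substituent on that phenyl ring, and every one of them stayed within the scatter. On that basis the step of a 1.0-fold lower number from compound 3 to compound 4 (0.00 log units; within the scatter) is expected to be small, in no clear direction, and to stay within the scatter. Compound 4 is therefore estimated at 2900 nM in this assay, with a range from 1400 nM to 6000 nM.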

Compound 4, half-maximal inhibitory concentration: 7370 nM
Beside the measured number, compound 4's estimate is 2.5-fold (0.41 log units) below it, and the stated range ends below it.
By their numbers in this assay, from the lowest: compounds 2, 3 and 1 (each within the scatter of the next); then compound 4.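

In this assay, the group on the aromatic nitrogen of the five-membered ring with 3 nitrogen now makes a measurable difference: with 2-fluorophenyl there, a 2.5-fold higher number from compound 3 to compound 4 (0.40 log units; beyond the scatter) and a 3.9-fold higher number from compound 2 to compound 4 (0.60 log units; beyond the scatter) both stand beyond the scatter, whereas the three methylphenyl compounds could not be told apart. The closest comparison is 2-fluorophenyl against 2-methylphenyl, where a 2.3-fold higher number from compound 1 to compound 4 (0.36 log units; beyond the scatter) shows that this position responds to which substituent the phenyl ring carries, not only to where a methyl group stands, and that compound 4 is the weakest of the four, although each of these steps is modest. Nothing at hand gives a cause for these steps.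

The compounds shown leave open whether 3-fluorophenyl or 4-fluorophenyl would read like compound 4 or like the methylphenyl compounds, so the place of the fluorine cannot yet be separated from its presence. They also leave open how the same position would respond to a chlorine atom, a methoxy group or an amine on the phenyl ring, or to an unsubstituted phenyl.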